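A New Chain End on Compound 3

This account rests on a few compounds, and the source may have more. Where it says the series, first, only, none or still open, it means among the compounds named here.

Three related compounds have been measured in a physicochemical assay for solubility, in phosphate buffer, with a stated time of 18 h, at pH 7.4; on this read-out lower numbers stand for lower solubility and higher numbers for higher solubility. Compound 1 (`Nc1cc2c(-n3nc(-c4ccccn4)nc3N)ncnc2cc1Cl`) gives 3000 nM and compound 2 (`COc1cc2nc(-c3ccccc3)nc(-n3nc(-c4ccccn4)nc3N)c2cc1OC`) gives 2000 nM, two values that lie within the usual scatter of each other. Compound 3 (`COc1cc2ncnc(-n3nc(-c4ccccn4)nc3N)c2cc1OCCCN(C)C`) stands highest of the three at 53000 nM, and its distance from each of the other two lies well beyond that scatter.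

Compound 4 (`CCOC(=O)NCCCOc1cc2c(-n3nc(-c4ccccn4)nc3N)ncnc2cc1OC`) has not yet been measured. It differs from compound 3 in one place: (ethoxycarbonyl)amino in place of dimethylamino on a saturated chain carbon, three bonds along the chain from an oxygen on an aromatic ring. Here (ethoxycarbonyl)amino stands in place of dimethylamino on a saturated chain carbon, three bonds along the chain from an oxygen on an aromatic ring.

Among the measured compounds shown here, no two measured compounds differ in one place only, so this swap has no direct precedent and any forecast is a rough one. Of the three, only compound 3 carries dimethylamino, while compound 1 at 3000 nM and compound 2 at 2000 nM lack it, though they also differ from compound 3 elsewhere. A fall in this assay beyond the scatter is therefore expected, and the estimated step is an 11-fold lower number from compound 3 to compound 4 (1.03 log units; beyond the scatter). The estimate for compound 4 is 5000 nM, with an expected range from 1500 nM to 20000 nM.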

Compound 4, solubility: 16000 nM
Beside the measured number, compound 4's estimate is 3.2-fold (0.51 log units) below it; measured number inside the range.
By their numbers in this assay, from the lowest: compounds 2 and 1 (each within the scatter of the next); then compound 4; then compound 3.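

Among the compounds shown here, compounds 3 and 4 are the only pair here that differ in one place, which gives the first direct reading of a change at this chain end in this assay: there is a 3.3-fold lower number from compound 3 to compound 4 (0.52 log units; beyond the scatter), a modest step but one that lies beyond the usual scatter. The read-out therefore responds to the group carried on a saturated chain carbon, three bonds along the chain from an oxygen on an aromatic ring, even though the rest of the molecule stays the same. The swap changes several things at once, replacing 3 heavy atoms with 6 and bringing in a double bond and a hydrogen-bond donor, and no measurement here explains why the number moves.

Going by these compounds, what remains open is which part of the swap accounts for the step, and whether losing dimethylamino or gaining (ethoxycarbonyl)amino matters more. A primary amine, an acetamide or a carboxylic acid on the same propyl chain, or dimethylamino on a longer chain, would each separate these parts of the change more finely.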